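The source may hold more compounds than are shown below. What is called first, only, known or untested is meant among the compounds shown, and "the series" means these compounds.

Compound 1 `C[C@@H](Nc1c(NCCCCCC(=O)NO)c(=O)c1=O)c1ccccc1` was run through an ADME assay on cells (Hepatocyte, Homo sapiens) for pharmacokinetics, read by LC-MS, with a stated time of 90 min, tested at 1 uM; a higher number here means faster removal of the compound, a lower number slower removal. In this assay compound 1 gives < 5 uL/min, which is a limit of the assay and not a number. Two close relatives were measured as well. Compound 2 `Cc1cccc([C@@H](C)Nc2c(NCCCCCC(=O)NO)c(=O)c2=O)c1` gives < 5 uL/min, again a limit. Compound 3 `Cc1ccc([C@H](C)Nc2c(NCCCCCC(=O)NO)c(=O)c2=O)cc1` gives < 5 uL/min, also a limit. Within the data shown here, the only step that can be drawn between measured compounds, a step that the two limits leave unreadable from compound 1 to compound 2, therefore cannot be sized, since both of its ends sit at the limit of < 5 uL/min in this assay, at which 3 of the 3 values shown sit. Compound 4 `Cc1cccc(Nc2c(NCCCCCC(=O)NO)c(=O)c2=O)c1` has not yet been measured. It differs from compound 1 in one place: 3-methylphenyl in place of 1-phenylethyl on a nitrogen on an aromatic ring. Among the measured compounds shown here, no measured step concerns a change of this kind, and the one step that exists is unreadable, so there is no basis for expecting a shift beyond the usual scatter in either direction. Every value shown sits at the same limit (the limit of < 5 uL/min in this assay, at which 3 of the 3 values shown sit). Compound 4 is accordingly expected to give 4 uL/min, with a range from 1 uL/min to 12 uL/min. That amounts to an expected step that the limit leaves unreadable from compound 1 to compound 4.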

Compound 4, intrinsic clearance in a liver preparation (reported as CLH), per the amount of preparation that the assay uses in the Hepatocyte assay: 18 uL/min
Beside the measured number, compound 4's estimate is 4.5-fold (0.65 log units) below it; measured number outside the range, above it.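

Unlike the earlier step, which cannot be read, this change gives a readable result in the Hepatocyte assay, with 3-methylphenyl in place of 1-phenylethyl on the nitrogen: an at least 3.6-fold higher number from compound 1 to compound 4 (0.55 log units; beyond the scatter). In a physicochemical assay for solubility, with a stated time of 24 h, tested at 30 mg/mL (a lower number here means a less soluble compound, a higher number a more soluble compound), compound 1 gives 39000000 nM and compound 4 gives 11000000 nM. The same change thus goes with lower solubility as well as faster removal, so this position affects both read-outs: the measured solubility of compound 1, 39000000 nM, and of compound 4, 11000000 nM, a 3.5-fold lower number (0.55 log units; beyond the scatter)

The change swaps the whole group and also removes the defined stereocentre of 1-phenylethyl, and the compounds shown cannot separate these differences. On these data alone, whether a benzyl or an unsubstituted phenyl group on this nitrogen would behave like compound 4 or like compound 1 remains open.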